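Two Extra Double Bonds in a Long Ester Chain

The source may hold more compounds than are shown below. What is called first, only, known or untested is meant among the compounds shown, and "the series" means these compounds.

Compound 1, `CCCCCCCC/C=C\CCCCCCCC(=O)OCC1CCCCO1`: in an assay on membranes from cerebellum for inhibition of Fatty-acid amide hydrolase 1 (Rattus norvegicus) (a lower number here means a stronger inhibitor, a higher number a weaker inhibitor), compound 1 gives 29000 nM.
Compound 2, `O=C(OCC1CCCCO1)c1ccc(-c2ccccc2)cc1`: in this assay compound 2 gives 32000 nM.

Compound 1 and compound 2 share the same ester core and differ only in the acid part, a long chain with one double bond in compound 1 and a two-ring acid in compound 2. Their two values lie within the usual scatter of each other, so neither can be called the stronger or weaker inhibitor on these numbers; both are high.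

The unmeasured compound 3, `CC/C=C\C/C=C\C/C=C\CCCCCCCC(=O)OCC1CCCCO1`, keeps the chain of compound 1 and alters it in one place: hepta-1,4-dien-1-yl in place of heptyl on a saturated chain carbon bound to a double-bonded chain carbon. Among the measured compounds shown here, no measured pair shows what this kind of change does in this assay, so the expectation rests on the two high numbers alone. Adding double bonds to an already long chain is expected to move the number only modestly, toward a lower value if at all, and not clearly beyond the scatter. Compound 3 is therefore estimated at 18000 nM, with a range from 6000 nM to 50000 nM, an expected step of a 1.6-fold lower number from compound 1 to compound 3 (0.21 log units; within the scatter).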

Compound 3, half-maximal inhibitory concentration: 19000 nM
The estimate for compound 3 lay 1.1-fold (0.02 log units) below the measured number; the range from low to high includes it.
By their numbers in this assay, from the lowest: compounds 3, 1 and 2 (each within the scatter of the next).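

Replacing heptyl with hepta-1,4-dien-1-yl on a saturated chain carbon bound to a double-bonded chain carbon gives, in this assay, a 1.5-fold lower number from compound 1 to compound 3 (0.18 log units; within the scatter), so this pair does not separate the two chains. Heptyl and hepta-1,4-dien-1-yl both hold 7 carbon atoms, which means this comparison changes the double bonds while keeping the carbon count of the group, and at this position the added double bonds produce no step beyond the scatter. No independent measurement is available to bear on this result.

From the compounds shown here alone, whether a different end to the chain, such as an amine or a carboxylic acid, would move the number beyond the scatter remains open, as does the effect of a longer chain or a shorter one at this same position. Also open, going by these compounds, is whether an amide in place of the ester link of compound 1 would give a clearly different number, or whether the shared core would keep all such compounds in the same high range.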